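Replacing the pyrimidinylsulfanyl chain by hydroxy on the shared core

This account rests on a few compounds, and the source may have more. Where it says the series, first, only, none or still open, it means among the compounds named here.

Measured in an assay on isolated protein (Oryctolagus cuniculus) with Thromboxane-A synthase (Homo sapiens) as the target, tested at 1 uM; a lower number here means less inhibition, a higher number more inhibition at the concentration tested (going by the name of the read-out):
compound 1 `CC(C)n1nc(-c2cccnc2)c2ccccc2c1=O`: 87%
compound 2 `O=c1c2ccccc2c(-c2cccnc2)nn1CCSc1ncccn1`: 86%
compound 3 `O=c1c2ccccc2c(-c2cccnc2)nn1CCCCSc1ncccn1`: 96%

Compound 3 gives the largest of the three numbers, but neither gap reaches beyond the scatter: compound 1 sits nearest, compound 2 furthest, both within it. Among the compounds with values here, the one step between neighbours, a number 10 percentage points higher from compound 2 to compound 3 (within the scatter), lengthens the chain that carries the pyrimidine and changes nothing beyond the scatter.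

Compound 4 `O=c1c2ccccc2c(-c2cccnc2)nn1CCO` is not yet measured. It differs from compound 3 as follows: hydroxy in place of 2-((pyrimidin-2-yl)sulfanyl)ethyl on a saturated chain carbon, two bonds along the chain from an aromatic nitrogen. Within the data shown here, no measured step removes the pyrimidine-bearing chain altogether, so the bearing is indirect. Compound 1, which carries isopropyl in this place, shows that a small substituent on that nitrogen is compatible with high inhibition at the concentration tested, given 87%; and the lengthening step a number 10 percentage points higher from compound 2 to compound 3 (within the scatter) shows that chain length alone matters little here. Hydroxy is, however, smaller than either of those groups, and a modest loss is plausible.

The expected step is a number 24 percentage points lower from compound 3 to compound 4 (beyond the scatter), a decrease of uncertain size. For compound 4 the estimate in this assay is 72%, with a range from 45% to 92%.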

Compound 4, a percentage reported as inhibition, at one concentration (the size of the read-out at that concentration, not a potency): 69%
For compound 4 the middle estimate is 3 percentage points above the measured one; low and high end bracket the measured number.
By their numbers in this assay, from the lowest: compound 4; then compounds 2, 1 and 3 (each within the scatter of the next).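

In this assay, this position now shows its first change beyond the scatter: with hydroxy in place of 2-((pyrimidin-2-yl)sulfanyl)ethyl on a saturated chain carbon, the series gives a number 27 percentage points lower from compound 3 to compound 4 (beyond the scatter), and with hydroxy in place of (pyrimidin-2-yl)sulfanyl it gives a number 17 percentage points lower from compound 2 to compound 4 (beyond the scatter), whereas lengthening the chain had not moved the number beyond the scatter. Small size alone does not account for the level seen at this aromatic nitrogen, since 2-hydroxyethyl in place of isopropyl gives a number 18 percentage points lower from compound 1 to compound 4 (beyond the scatter), yet without any pyrimidine compound 4 still gives 69%, so the pyrimidine is not required for substantial inhibition at the concentration tested. No measurement on hand explains this loss.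

From the compounds shown here alone, it remains open whether an ethyl group, or an amine or a carboxylic acid at the end of the same chain, would sit with compound 4 or with compounds 1, 2 and 3. A reading at one concentration also leaves open how potency compares among compounds 1, 2 and 3, whose numbers lie within the scatter of one another.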